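A Methyl Added to the Oxadiazole of Compound 1

The source may hold more compounds than are shown below. What is called first, only, known or untested is meant among the compounds shown, and "the series" means these compounds.

Measured so far:
Compound 1, `CCCN(CCC)C[C@@H](C)NC(=O)c1ccc(-c2ncon2)cc1`, in an assay on Jurkat E6.1 cells for inhibition of histone deacetylase 4 (Homo sapiens), read by fluorescence; a higher number here means a weaker inhibitor, a lower number a stronger inhibitor: > 50000 nM, which is a limit of the assay and not a number.
Compound 2, `O=C(NC1(CN2CCCC2)CC1)c1ccc(-c2noc(C(F)(F)F)n2)cc1`, in this assay: 180 nM.

Compound 1 stands at the limit of this assay (the limit of > 50000 nM in this assay, at which 1 of the 2 values shown sits); no half-maximal inhibitory concentration was reached for it. Compound 2 differs from compound 1 in several places at once. Among the compounds with values here, the value of compound 2, 180 nM, therefore shows only that a compound of this kind can be measured, not what any single change does.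

Compound 3, `CCCN(CCC)C[C@@H](C)NC(=O)c1ccc(-c2noc(C)n2)cc1`, differs from compound 1 in one place: methyl in place of hydrogen on an aromatic carbon. Within the data shown here, no measured pair isolates this change, so the step from compound 1 to compound 3 is expected to be small, at most within the scatter or a modest gain, and compound 3 is expected to remain weak: an at least 1.2-fold lower number from compound 1 to compound 3 (0.09 log units; that floor lies within the scatter). Compound 3 is estimated at 40000 nM, between 8000 nM and 200000 nM.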

Compound 3, half-maximal inhibitory concentration: > 50000 nM
Compound 3: only a limit was reported (the forecaster's own chance of this, stated with the estimate: 55%); middle value at least 1.2-fold (0.09 log units) from the limit.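

Compound 3 gives > 50000 nM in this assay, which is a limit of the assay and not a number. Compound 1 carries a limit as well, so no step from it to compound 3 can be read: the limit of > 50000 nM in this assay, at which 2 of the 3 values shown sit.

On these data alone, what the methyl on the oxadiazole does to inhibition stays open, since neither compound reached a measurable half-maximal inhibitory concentration.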